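The source may report more compounds than this note shows. Statements on the series, on what has been measured and on what is new or still open speak of the compounds shown alone.

Of the compounds shown here, two of the shared core have been measured in a functional assay on SN12C cells (Homo sapiens) for inhibition, read by sulforhodamine B assay, with a stated time of 48 h, tested at 10 uM; on this read-out higher numbers stand for more inhibition at the one concentration tested (going by the name of the read-out) and lower numbers for less inhibition. Compound 1 `FC(F)(F)c1cccc(-c2cn3ccnc3c(-c3ccc4ncn(C5CCCCC5)c4c3)n2)c1` carries a trifluoromethyl-bearing aryl and a cyclohexyl on the imidazole nitrogen, and in this assay compound 1 gives 8.3%. Compound 2 `CCc1ccc(-c2cn3ccnc3c(-c3ccc4ncn(Cc5ccccc5)c4c3)n2)cc1` carries an ethyl-substituted aryl and a benzyl in place of the cyclohexyl, and in this assay compound 2 gives 22.5%. Compound 2 therefore stands highest of the two numbers seen so far, and the gap to compound 1 lies beyond the usual scatter of this kind of measurement, though both readings describe only modest inhibition at the single concentration tested.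

Compound 3 `O=Cc1ccc(-c2cn3ccnc3c(-c3ccc4ncn(Cc5ccccc5)c4c3)n2)cc1` is the next member of the series and has not yet been measured. It differs from compound 2 in a single place: formyl in place of ethyl on an aromatic carbon. Among the compounds with values here, no pair of measured compounds shows what this exchange does to the read-out, so no guidance exists beyond the level of compound 2 itself. Compound 3 is expected to show a step of a number 4.5 percentage points lower from compound 2 to compound 3 (within the scatter), that is, no movement beyond the scatter, with a small downward lean. Compound 3 is accordingly estimated at 18%, within a range from 4% to 34%.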

Compound 3, a percentage reported as inhibition, at one concentration (the size of the read-out at that concentration, not a potency): 20.7%
Compound 3: middle estimate off by 2.7 percentage points, on the low side; low and high end bracket the measured number.
By their numbers in this assay, from the lowest: compound 1; then compounds 3 and 2 (each within the scatter of the next).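

In this assay, within the data shown here, the change from 4-ethylphenyl to 4-formylphenyl gives a number 1.8 percentage points lower from compound 2 to compound 3 (within the scatter) and so provides the first reading of a single exchange, which the earlier pair, differing in more than one place, could not provide. At this position on the six-membered aromatic ring, para to a large group, replacing a carbon-only ethyl with a formyl that brings a double bond outside the aromatic rings and 1 hydrogen-bond acceptor does not move the read-out beyond the scatter, at least with the benzyl on the imidazole nitrogen. Nothing measured here accounts for this result.

The compounds shown leave open whether an amine, a carboxylic acid or a longer chain at this position would move the read-out beyond the scatter, and whether the formyl would behave the same way with the cyclohexyl in place of the benzyl. They also cannot say how the gap between compound 1 and compound 2 divides between the two places in which those compounds differ.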